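Isobutyl for isopropyl at the carbonyl carbon

This account rests on a few compounds, and the source may have more. Where it says the series, first, only, none or still open, it means among the compounds named here.

Two compounds have numbers in an assay on HEK293 cells for positive allosteric modulation of metabotropic glutamate receptor 3 (Rattus norvegicus), read by thallium flux, with a stated time of 2.5 min; on this read-out lower numbers stand for smaller maximal responses and higher numbers for larger maximal responses: compound 1 `Cc1c(OCCCCOc2ccc(C(=O)O)c(Cl)c2)ccc(C(=O)CC(C)C)c1O` gives 49.5%, and compound 2 `Cc1c(OCCCCOc2ccc(F)c(C(=O)O)c2)ccc(C(=O)C(C)C)c1O` gives 31.3%. Compound 2 stands lowest of the two, beyond the scatter below compound 1. Compound 3 `Cc1c(OCCCCOc2ccc(F)c(C(=O)O)c2)ccc(C(=O)CC(C)C)c1O` differs from compound 2 in one place: isobutyl in place of isopropyl on a carbonyl carbon. For the measured compounds named here, no measured pair shows this change by itself, so its size is not known from these data. A small upward step is expected, a number 8.7 percentage points higher from compound 2 to compound 3 (within the scatter), not clearly beyond the scatter. For compound 3 the expected value in this assay is 40%, with a range from 25% to 58%.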

Compound 3, largest response reached (reported as percent of maximum), in percent of the reference or control that the assay uses: 81.7%
Compound 3: the middle estimate sits 41.7 percentage points below what was measured; the whole stated range lies below it.
By their numbers in this assay, from the lowest: compound 2; then compound 1; then compound 3.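

The isobutyl for isopropyl change on the carbonyl carbon, taken alone, gives a number 50.4 percentage points higher from compound 2 to compound 3 (beyond the scatter) with the 3-carboxy-4-fluorophenyl group held fixed, so this position responds strongly to one added carbon. With isobutyl held fixed, the change at the other end of the molecule gives a number 32.2 percentage points higher from compound 1 to compound 3 (beyond the scatter) and shows that the aryl group on the oxygen also moves the maximal response. No available evidence explains either step.

Open, going by these compounds, is whether a longer chain such as neopentyl on the carbonyl carbon extends this rise or reverses it. Also open, on these data alone, is whether the isobutyl gain holds with 4-carboxy-3-chlorophenyl in place.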